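The compounds below may be only part of what the source reports. "The series", "measured", "known", "first", "only" and "open" are said of these compounds alone.

Compound 1 `COc1cc(/C=C2\CN(C)C/C(=C\c3ccccc3F)C2=O)cc(OC)c1`: 5450 nM
Compound 2 `CN1C/C(=C\c2ccc(C(C)(C)C)cc2)C(=O)/C(=C/c2ccccc2F)C1`: 15500 nM
Compound 3 `CN1C/C(=C\c2ccc(C(F)(F)F)cc2)C(=O)/C(=C/c2ccccc2F)C1`: 6560 nM

All three values come from a functional assay on HeLa cells (Homo sapiens) for cytotoxicity, read by MTT assay, with a stated time of 24 h; a lower number here means a stronger inhibitor, a higher number a weaker inhibitor. Compound 1 and compound 3 lie within the scatter of each other, so neither can be ranked ahead. Compound 2 stands beyond the scatter from both, with the highest number of the three.

Compound 4 `COc1cc(/C=C2\CN(C)C/C(=C\c3ccc(Br)cc3)C2=O)cc(OC)c1` has not yet been measured. It keeps the rest of compound 1 and differs in one place: 4-bromophenyl in place of 2-fluorophenyl on a double-bonded chain carbon bound to a double-bonded ring carbon. Within the data shown here, the only measured step, a 2.4-fold lower number from compound 2 to compound 3 (0.37 log units; beyond the scatter), puts trifluoromethyl in place of tert-butyl on an aromatic carbon, and it is modest. It bears on the new change only loosely. Among the measured compounds shown here, compound 2 and compound 3 both keep the 2-fluorophenyl, and no measured pair shows that group leaving or the 4-bromophenyl entering.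

For the measured compounds named here, the modest size of that one step is therefore the only guide, and it gives no direction. A change of similar size either way is possible, but none beyond the scatter is the likeliest outcome in this assay. The expected step is a 1.1-fold lower number from compound 1 to compound 4 (0.04 log units; within the scatter). For compound 4 the estimated value is 5000 nM, with an expected range from 2200 nM to 11500 nM.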

Compound 4, half-maximal inhibitory concentration: 5900 nM
Beside the measured number, compound 4's estimate is 1.2-fold (0.07 log units) below it; low and high end bracket the measured number.
By their numbers in this assay, from the lowest: compounds 1, 4 and 3 (each within the scatter of the next); then compound 2.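

In this assay, putting 4-bromophenyl in place of 2-fluorophenyl on a double-bonded chain carbon bound to a double-bonded ring carbon gives a 1.1-fold higher number from compound 1 to compound 4 (0.03 log units; within the scatter), the first step read at this position. On the core of compound 1, then, the two halogen-bearing phenyl groups cannot be told apart in this assay, even though the halogen and its place on the phenyl ring both differ, while the groups match in their counts of heavy atoms, hydrogen-bond donors and hydrogen-bond acceptors. No measurement here offers an explanation for this result.

The compounds shown leave open whether the identity of the halogen and its place on the ring each matter separately, with a pair such as 4-fluorophenyl and 2-bromophenyl needed to separate the two, and whether the same result would hold with the tert-butyl or trifluoromethyl phenyl groups of compound 2 and compound 3 on the other side of the core. They also leave open how this position would respond to a phenyl group carrying an amine or a carboxylic acid instead of a halogen.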